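The source may report more compounds than this note shows. Statements on the series, on what has been measured and on what is new or still open speak of the compounds shown alone.

Measured so far:
compound 1 `COc1cc(Cl)cc(-c2nn(-c3cccc(NC(=O)Nc4ccc(Cl)c(C(F)(F)F)c4)c3)cc2-c2ccncc2)c1` — -1.17%
compound 2 `COc1cc(Cl)cc(-c2nn(-c3cccc(NC(=O)Nc4cc(C(F)(F)F)cc(C(F)(F)F)c4)c3)cc2-c2ccncc2)c1` — -17.7%

Both compounds were tested in a functional assay on SF-539 cells (Homo sapiens) for inhibition, read by sulforhodamine B assay, with a stated time of 48 h, tested at 10 uM; on this read-out higher numbers stand for a weaker effect at the one concentration tested and lower numbers for a stronger effect. Compound 1 gives -1.17%, and compound 2 gives -17.7%, the lowest of the two numbers; the gap to compound 1 lies beyond the usual scatter of this kind of measurement, so compound 2 stands as the stronger of the two.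

Compound 3 `COc1cc(Cl)cc(-c2nn(-c3cccc(NC(=O)Nc4cccc(C(F)(F)F)c4)c3)cc2-c2ccncc2)c1` has not yet been measured. It is made from compound 2 by one change: hydrogen in place of trifluoromethyl on an aromatic carbon. The aromatic carbon that now carries hydrogen sits meta to a large group and meta to the remaining trifluoromethyl group. Among the measured compounds shown here, no step between measured compounds shows what this change does, so the expectation rests on the two values alone. Because compound 1, with one trifluoromethyl and a different neighbour, gives -1.17%, losing a trifluoromethyl group is expected to weaken the effect by a moderate step, from compound 2 to compound 3 estimated at a number 22.7 percentage points higher from compound 2 to compound 3 (beyond the scatter). Compound 3 is therefore expected to give about 5%, within a range from -12% to 25%.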

Compound 3, a percentage reported as activity, at one concentration (the size of the read-out at that concentration, not a potency): 17%
Compound 3: the middle estimate sits 12 percentage points below what was measured; measured number inside the range.
By their numbers in this assay, from the lowest: compound 2; then compound 1; then compound 3.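

In this assay this aromatic carbon is clearly sensitive to what it carries: hydrogen in place of trifluoromethyl gives a number 34.7 percentage points higher from compound 2 to compound 3 (beyond the scatter) and so a much weaker effect. Hydrogen in place of chloro on an aromatic carbon also weakens the effect, giving a number 18.2 percentage points higher from compound 1 to compound 3 (beyond the scatter) as a smaller but still real step, which leaves compound 3, with its single trifluoromethyl group, the weakest of the three. Nothing available explains why either loss weakens the effect.

On these data alone, whether a different group on this aromatic carbon, such as an amine or a carboxylic acid, would restore the effect remains open. As far as these compounds go, it is also open what would happen if the remaining trifluoromethyl group were replaced by hydrogen as well.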